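Fluoro for methyl in a cytotoxicity series

This account rests on a few compounds, and the source may have more. Where it says the series, first, only, none or still open, it means among the compounds named here.

The values in an ADME assay on BaF3 cells (Mus musculus) for cytotoxicity (a higher number here means that more compound is needed for the effect, a lower number that less compound is needed), are as follows.

- Compound 1 `O=C(Nc1nc2ccc(-c3cccc(C(=O)Nc4cccc(C(F)(F)F)c4)c3)nc2s1)NC1CCNCC1` gives > 10000 nM as a limit
- Compound 2 `O=C(Nc1ccc(N2CCNCC2)c(C(F)(F)F)c1)c1cccc(-c2ccc3nc(NC(=O)C4CC4)sc3n2)c1` gives 2300 nM as a number
- Compound 3 `CCN1CCN(Cc2ccc(NC(=O)c3ccc(C)c(-c4ccc5nc(NC(=O)C6CC6)sc5n4)c3)cc2C(F)(F)F)CC1` gives 1230 nM as a number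

The value of compound 1 is a limit of the assay and not a number. Compound 2 gives 2300 nM in this assay and lies within the scatter of compound 3, which gives 1230 nM in the same assay.

Compound 4 (`CCN1CCN(Cc2ccc(NC(=O)c3ccc(F)c(-c4ccc5nc(NC(=O)C6CC6)sc5n4)c3)cc2C(F)(F)F)CC1`) has not yet been measured. It differs from compound 3 by fluoro in place of methyl on an aromatic carbon, ortho to a large group and para to a large group. Among the compounds with values here, no two measured compounds differ in one place only, so no measured step speaks to this change. In this assay no step beyond the scatter is expected, in either direction. The expectation takes compound 3 at 1230 nM as its anchor. The expected step is a 1.1-fold higher number from compound 3 to compound 4 (0.02 log units; within the scatter) on this reading. For compound 4 the estimated value is 1300 nM with an expected range from 550 nM to 3200 nM in this assay.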

Compound 4, half-maximal effective concentration: > 10000 nM
Compound 4: only a limit was reported; the forecaster's own chance of this, stated with the estimate: 5%; middle value at least 7.6-fold (0.88 log units) from the limit.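

Fluoro in place of methyl on this aromatic carbon, ortho to a large group and para to a large group, gives an at least 8.1-fold higher number from compound 3 to compound 4 (0.91 log units; beyond the scatter) in this assay, the first one-place step in the series. Compound 4 gives > 10000 nM, which is a limit of the assay and not a number. This exchange of one heavy atom thus carries compound 4 to the end of the readable range, and the true size of the step stays unknown: the limit of > 10000 nM in this assay, at which 2 of the 4 values shown sit.

The compounds shown leave open whether the step follows from losing the methyl or from gaining the fluoro, as only these two groups are seen at this place, and a hydrogen, a chloro or a methoxy there could separate the two. They also leave open whether the same exchange gives a similar step with a different amine in the side chain of compound 3.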